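Shifting the Halogen on the Benzyl Arm

The source may hold more compounds than are shown below. What is called first, only, known or untested is meant among the compounds shown, and "the series" means these compounds.

Three measured compounds share one core and differ only in the benzyl group on the triazole nitrogen. Compound 1 `O=C(/C=C/c1ccc(OCc2cn(Cc3ccccc3)nn2)cc1)c1ccc([N+](=O)[O-])cc1` carries a plain benzyl group; in a functional assay on MIA PaCa-2 cells (Homo sapiens) for inhibition, read by MTT assay, with a stated time of 48 h, tested at 10 uM (on this read-out lower numbers stand for less inhibition of growth and higher numbers for more inhibition of growth at the one concentration tested), compound 1 gives "not active" (no number reported). Compound 2 `O=C(/C=C/c1ccc(OCc2cn(Cc3ccccc3Br)nn2)cc1)c1ccc([N+](=O)[O-])cc1` carries a 2-bromophenyl on that chain carbon, and in this assay compound 2 gives 34%. Compound 3 `O=C(/C=C/c1ccc(OCc2cn(Cc3ccc(Br)cc3)nn2)cc1)c1ccc([N+](=O)[O-])cc1` carries a 4-bromophenyl instead, and in this assay compound 3 gives 17%. The step of a number 17 percentage points lower from compound 2 to compound 3 (beyond the scatter) shows that where the bromine sits matters, and compound 3 stands lowest of the two numbers that were reported, with compound 1 giving no number at all.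

Compound 4 `O=C(/C=C/c1ccc(OCc2cn(Cc3cccc(F)c3)nn2)cc1)c1ccc([N+](=O)[O-])cc1` is not yet measured. Its change from compound 3 is 3-fluorophenyl in place of 4-bromophenyl on a saturated chain carbon bound to an aromatic nitrogen. Among the measured compounds shown here, no measured step exchanges bromine for fluorine, so the only guide is the modest size of the step from compound 2 to compound 3 and the absence of activity for compound 1. The expected step of a number 2 percentage points lower from compound 3 to compound 4 (within the scatter) is therefore small and uncertain in direction. Compound 4 is estimated at 15% in this assay, with a range from 0% to 35%.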

Compound 4, percent growth inhibition at one concentration: 32%
For compound 4 the middle estimate is 17 percentage points below the measured one, and the stated range covers the measured number.
By their numbers in this assay, from the lowest: compound 3; then compounds 4 and 2 (each within the scatter of the next).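

The a number 15 percentage points higher from compound 3 to compound 4 (beyond the scatter) shows that, in this assay, the 4-bromophenyl is not the limit of this benzyl arm: another halogen-bearing ring on the same saturated chain carbon restores a clearly higher number. The a number 2 percentage points lower from compound 2 to compound 4 (within the scatter) puts 3-fluorophenyl and 2-bromophenyl level with each other, so two rings that differ in both halogen and ring position cannot be told apart here, and compound 3 is the one that stands apart among the compounds with numbers. All three halogen-bearing compounds give a number, whereas compound 1, with its plain benzyl group, gives "not active" (no number reported), and no measurement at hand explains any of these differences.

Going by these compounds, the step from compound 3 to compound 4 changes the halogen and its ring position together, so the share of each in the change stays unknown. On these data alone, it also remains open how this arm would respond to a chlorophenyl, or to a ring carrying an amine or a carboxylic acid, and whether any such group could lift the number much beyond those seen so far.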